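The compounds below may be only part of what the source reports. "The series", "measured", "known", "first", "only" and "open" are said of these compounds alone.

Compound 1 `O=C1Nc2ccc(Br)cc2/C1=N/NC(=S)N1CCN(c2ccccc2)CC1` and compound 2 `O=C1Nc2ccc(Cl)cc2/C1=N/NC(=S)N1CCN(c2ccccc2)CC1` share one core and differ only by chloro in place of bromo on an aromatic carbon. In a functional assay on MCF7 cells (Homo sapiens) for inhibition, read by MTT assay, with a stated time of 72 h (a lower number here means a stronger inhibitor, a higher number a weaker inhibitor), compound 1 gives 20500 nM, while compound 2 gives 10400 nM; the exchange of halogen made a 2.0-fold lower number from compound 1 to compound 2 (0.29 log units; within the scatter). Compound 3 `O=C1Nc2cc(Br)ccc2/C1=N/NC(=S)N1CCN(c2ccccc2)CC1` is built from the same atoms as compound 1, joined differently; the difference between the two cores is not broken down here. In this assay compound 3 gives 19700 nM, close to the number of compound 1. Compound 4 `O=C1Nc2cc(Cl)ccc2/C1=N/NC(=S)N1CCN(c2ccccc2)CC1` has not been measured; it differs from compound 3 by chloro in place of bromo on an aromatic carbon, the same change that turns compound 1 into compound 2. The estimate for compound 4 means a 1.8-fold lower number from compound 3 to compound 4 (0.25 log units; within the scatter), which rests on a 2.0-fold lower number from compound 1 to compound 2 (0.29 log units; within the scatter). Compound 4 is therefore expected to give 11000 nM in this assay, with a likely range from 5500 nM to 22000 nM.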

Compound 4, half-maximal inhibitory concentration: 23000 nM
Compound 4: middle estimate off by 2.1-fold (0.32 log units), on the low side, outside the stated range (above it).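

In this assay, chloro in place of bromo on an aromatic carbon gives a 1.2-fold higher number from compound 3 to compound 4 (0.07 log units; within the scatter). Set beside the earlier step, the two cores cannot be told apart: the same change on two cores in this assay, a 2.0-fold lower number (0.29 log units; within the scatter) from compound 1 to compound 2 and a 1.2-fold higher number (0.07 log units; within the scatter) from compound 3 to compound 4, 2.3-fold (0.36 log units) apart, within the scatter of two such steps. So the exchange of halogen stays within the scatter on both cores and nothing marks it as behaving differently on one of them, but this does not show that the change carries a real effect from core to core, as neither step stands clear of the scatter of repeated measurements.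

The compounds shown leave open how fluoro, methoxy or an amine on that aromatic carbon would read in this assay. They also leave open whether any such group would move the number beyond the scatter on either core.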